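The compounds below may be only part of what the source reports. "The series", "measured", "known", "first", "only" and "open" are said of these compounds alone.

Series notes. In an ADME assay on a cell-free system (plasma, Mus musculus) for metabolic stability, read by HPLC, with a stated time of 120 min, tested at 2 uM (on this read-out higher numbers stand for a longer-lived compound and lower numbers for a shorter-lived compound), compound 3 `Cc1ccc(CNC(=O)n2c(N)nc3ccccc32)cc1` reaches only a limit, < 0.0834 h. Compound 1 `Cc1ccccc1CNC(=O)n1c(N)nc2ccccc21` likewise gives only a limit in this assay, < 0.0834 h. Compound 2 `Cc1nc2ccccc2n1C(=O)NCCCCc1ccccc1`, built on a different core, gives 0.183 h in this assay. Among the measured compounds shown here, the one measured step with a structural parallel, a step that the two limits leave unreadable from compound 1 to compound 3, cannot be sized, since both of its ends rest on (the limit of < 0.0834 h in this assay, at which 2 of the 3 values shown sit).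

Compound 4 `Cc1cccc(CNC(=O)n2c(N)nc3ccccc32)c1` differs from compound 3 by 3-methylphenyl in place of 4-methylphenyl on a saturated chain carbon bound to an amide-type nitrogen. Shifting the methyl on the phenyl gave no readable step before, and two of three values in this assay sit at the limit of < 0.0834 h in this assay, at which 2 of the 3 values shown sit, so no step beyond the scatter is expected. Compound 4 is therefore expected at 0.06 h, in the range 0.02 h to 0.15 h, most likely again only a limit. The estimated step is a step that the limit leaves unreadable from compound 3 to compound 4, which is no change worth reading.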

Compound 4, half-life: < 0.0834 h
Compound 4: no number, only a limit; the forecaster's own chance of this, stated with the estimate: 70%; the middle value does not contradict the limit.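

Among the compounds shown here, no step among compound 1, compound 3 and compound 4 can be read in this assay, as all three rest on a limit: the limit of < 0.0834 h in this assay, at which 3 of the 4 values shown sit. Going by these compounds, whether 2-methylphenyl, 3-methylphenyl and 4-methylphenyl differ at all in half-life stays open.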